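This account rests on a few compounds, and the source may have more. Where it says the series, first, only, none or still open, it means among the compounds named here.

Measured so far:
compound 1 `Fc1ccc([C@@H]2NCCOC23COC[C@H](c2cccc(C(F)(F)F)c2)C3)cc1`: 30 nM
compound 2 `COc1ccccc1[C@H]1COCC2(C1)OCCN[C@H]2c1ccc(F)cc1`: 13 nM
compound 3 `COc1ccc(F)cc1[C@H]1COCC2(C1)OCCN[C@H]2c1ccc(F)cc1`: 10 nM

In an assay on CHO cells for displacement of a labelled ligand from Substance-P receptor (Homo sapiens) (a lower number here means a stronger inhibitor, a higher number a weaker inhibitor), compound 3 gives the lowest of the three numbers; compound 2 lies within the scatter of it, while compound 1 lies beyond the scatter, at a higher number. Among the measured compounds shown here, the only single-point step is a 1.3-fold lower number from compound 2 to compound 3 (0.11 log units; within the scatter), which stays within the scatter. Compound 4 `Fc1ccc([C@@H]2NCCOC23COC[C@H](c2ccccc2)C3)cc1` differs from compound 3 by phenyl in place of 5-fluoro-2-methoxyphenyl on a saturated ring carbon, so both the fluoro and the methoxy leave. For the measured compounds named here, no measured step covers loss of the methoxy. Compound 1 and compound 2 carry different aryl groups on the same core, and compound 1 shows the higher number. Compound 4 is therefore expected to give a higher number, a 3.0-fold higher number from compound 3 to compound 4 (0.48 log units; beyond the scatter). The estimate for compound 4 is 30 nM, with a range from 10 nM to 90 nM.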

Compound 4, half-maximal inhibitory concentration: 99 nM
Estimate against measurement, compound 4: 3.3-fold (0.52 log units) below, and the stated range ends below it.
By their numbers in this assay, from the lowest: compounds 3 and 2 (each within the scatter of the next); then compound 1; then compound 4.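

In this assay, among the compounds shown here, the bare phenyl on this saturated ring carbon gives the highest number so far, with a 9.9-fold higher number from compound 3 to compound 4 (1.00 log units; beyond the scatter); the aryl substituents therefore matter at this position, which the earlier compounds could not show. Hydrogen in place of methoxy gives a 7.6-fold higher number from compound 2 to compound 4 (0.88 log units; beyond the scatter), and hydrogen in place of trifluoromethyl gives a 3.3-fold higher number from compound 1 to compound 4 (0.52 log units; beyond the scatter), so either substituent gives a lower number than none. Nothing measured here explains these steps. Still open, on these data alone, is whether fluoro alone on the phenyl lowers the number, and whether ethoxy, hydroxy or an amine can stand in place of methoxy.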